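This account rests on a few compounds, and the source may have more. Where it says the series, first, only, none or still open, it means among the compounds named here.

Working notes on three measured compounds and one awaiting measurement in an ADME assay on PBMC cells (Homo sapiens) for cytotoxicity; a lower number here means that less compound is tolerated, a higher number that more compound is tolerated. Compound 1 `CCO/N=C(/c1ccc(Br)cc1)C1CCN(C(C)CCNC(=O)c2c(Cl)cncc2Cl)CC1` gives 33800 nM, and compound 3 `CCO/N=C(/c1ccc(Br)cc1)C1CCN(C(C)(C)CCNC(=O)c2c(Cl)cncc2Cl)CC1` gives 34000 nM. Compound 2 `CC(CCNC(=O)c1c(Cl)cncc1Cl)N1CCC(C(Oc2ncccc2Cl)c2ccc(C(F)(F)F)cc2)CC1` gives 16700 nM, the lowest number of the three, with compound 1 nearest to it and compound 3 furthest. Going by the values given here, the single step between compounds that differ in one place is a 1.0-fold higher number from compound 1 to compound 3 (0.00 log units; within the scatter), which concerns a different part of the shared core and says nothing directly about the ether-linked aromatic ring of compound 2. Compound 4 `CC(CCNC(=O)c1c(Cl)cncc1Cl)N1CCC(C(Oc2ccccc2C#N)c2ccc(C(F)(F)F)cc2)CC1` differs from compound 2 by 2-cyanophenyl in place of 3-chloropyridin-2-yl on an oxygen on a saturated carbon. Among the compounds with values here, no measured step bears on this exchange of one aromatic ring for another on the ether oxygen; the only guide is that the one change tested so far in this assay, from compound 1 to compound 3, moved nothing beyond the scatter. Compound 4 is therefore expected to remain close to compound 2. The expected step is a 1.0-fold higher number from compound 2 to compound 4 (0.01 log units; within the scatter). The estimate for compound 4 in this assay is 17000 nM, with a range from 7000 nM to 40000 nM.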

Compound 4, half-maximal cytotoxic concentration: 17000 nM
Compound 4: middle estimate and measured number agree at the digits printed; measured number inside the range.
By their numbers in this assay, from the lowest: compounds 2, 4, 1 and 3 (each within the scatter of the next, the first and the last beyond it).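

In this assay, going by these compounds alone, the first reading at this position is a 1.0-fold higher number from compound 2 to compound 4 (0.01 log units; within the scatter), for 2-cyanophenyl in place of 3-chloropyridin-2-yl on an oxygen on a saturated carbon. The earlier step concerned a chain carbon bound to the amine nitrogen, whereas this one shows that an aromatic ring of carbon only bearing a nitrile and an aromatic ring with a hetero atom bearing chlorine are not told apart here on the ether oxygen. No measurement is available that would explain this result.

On these data alone, both groups are six-membered aromatic rings, so it remains open whether a saturated ring such as cyclohexyl, or a small group such as methyl, on the same oxygen would read the same. Also open, as far as these compounds go, is what separates compounds 1 and 3 from compound 2 and compound 4: these pairs differ in more than one place.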